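Swapping an Ester for an Alcohol on a Weak Compound

The source may report more compounds than this note shows. Statements on the series, on what has been measured and on what is new or still open speak of the compounds shown alone.

As far as these compounds go, in a functional assay on QGY cells (Homo sapiens) for cytotoxicity, read by MTT assay, with a stated time of 48 h (a higher number here means a weaker inhibitor, a lower number a stronger inhibitor), compound 3 `CCOC(=O)[C@@]1(C(=O)NCc2ccc(C)cc2)C[C@@H]1c1cc(OC)c(OC)c(OC)c1` gives only a limit, > 100000 nM, so its true value stays unknown. Compound 2 `COc1cc([C@H]2C[C@@]2(CO)C(=O)Nc2ccccc2)cc(OC)c1OC`, which carries hydroxymethyl, also gives only a limit, > 100000 nM. Compound 1 `COc1cc([C@@H]2C[C@]2(CO)C(=O)NCc2ccc(C)cc2)cc(OC)c1OC`, which also carries hydroxymethyl, gives an actual number, 25100 nM.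

Compound 4 `COc1cc([C@H]2C[C@@]2(CO)C(=O)NCc2ccc(C)cc2)cc(OC)c1OC` keeps the rest of compound 3 but has hydroxymethyl in place of ethoxycarbonyl on a saturated ring carbon. Within the data shown here, no measured pair of compounds shows this change directly, so any forecast is uncertain. Compound 1, at 25100 nM, suggests that a hydroxymethyl compound can give a measurable value, while compound 2 goes against that pattern. A moderate move towards stronger inhibition is therefore expected, and the estimated step is an at least 2.2-fold lower number from compound 3 to compound 4 (0.34 log units; beyond the scatter). The result could still be another limit. For compound 4, the estimated value is 45000 nM, with an expected range from 15000 nM to 100000 nM.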

Compound 4, half-maximal inhibitory concentration: > 100000 nM
Compound 4 ended at the assay's limit; the forecaster's own chance of this, stated with the estimate: 40%; middle value at least 2.2-fold (0.34 log units) from the limit.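

Hydroxymethyl in place of ethoxycarbonyl on this saturated ring carbon does not by itself bring a readable value in this assay, and the steps to compound 4 from compound 3 and from compound 2 cannot be read, since both ends of each are limits. Among these compounds, the one readable step is an at least 3.9-fold higher number from compound 1 to compound 4 (0.60 log units; beyond the scatter), so hydroxymethyl gives a measurable value here only in the configuration drawn for compound 1. That difference can be put down to configuration alone because nothing else changes: the fact that compounds 1 and 4 differ only in the configuration as drawn.

As far as these compounds go, how far apart the two mirror images truly lie stays unknown, since compound 4 gives only a limit, as do most compounds here: the limit of > 100000 nM in this assay, at which 3 of the 4 values shown sit. Also open, from the compounds shown here alone, is whether an amine or a carboxylic acid on this ring carbon, in the configuration of compound 1, would give a lower number than hydroxymethyl.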